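Trimming the amide cap of a feruloyl chalcone

The compounds below may be only part of what the source reports. "The series", "measured", "known", "first", "only" and "open" are said of these compounds alone.

Compound 3 `COc1cc(/C=C/C(=O)c2cccc(NC(=O)c3ccc(Cl)cc3Cl)c2)ccc1O` gives 70% in a functional assay on HUVEC cells (Homo sapiens) for inhibition, tested at 10 ug/mL (a lower number here means a weaker effect, a higher number a stronger effect of the compound at the concentration tested), the second highest of the three values, sitting a number 12 percentage points higher from compound 1 to compound 3 (beyond the scatter) and a number 20 percentage points lower from compound 2 to compound 3 (beyond the scatter). Compound 1 `COc1cc(/C=C/C(=O)c2cccc(NC(=O)c3cc(Cl)cc(Cl)c3)c2)ccc1O` gives 58%, while compound 2 `COc1cc(/C=C/C(=O)c2cccc(N)c2)ccc1O` gives 90%. Compound 4 `COc1cc(/C=C/C(=O)c2cccc(NC(C)=O)c2)ccc1O` carries methyl in place of 2,4-dichlorophenyl on a carbonyl carbon. The bearing steps are a number 32 percentage points higher from compound 1 to compound 2 (beyond the scatter) and a number 20 percentage points lower from compound 2 to compound 3 (beyond the scatter), both showing the free aromatic amine of compound 2 stronger than either dichlorophenyl amide, and a number 12 percentage points higher from compound 1 to compound 3 (beyond the scatter), a smaller move between the two amides. Because a number 20 percentage points lower from compound 2 to compound 3 (beyond the scatter) spans the whole move from free amine to dichlorophenyl amide, while the acetyl of compound 4 keeps the amide but drops the 2,4-dichlorophenyl, compound 4 is expected to land partway along that move, a step of a number 8 percentage points higher from compound 3 to compound 4 (within the scatter) that may not exceed the scatter. Compound 4 is therefore estimated at 78%, within 60% to 92%.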

Compound 4, a percentage reported as inhibition, at one concentration (the size of the read-out at that concentration, not a potency): 32%
For compound 4 the middle estimate is 46 percentage points above the measured one; measured number outside the range, below it.
By their numbers in this assay, from the lowest: compound 4; then compound 1; then compound 3; then compound 2.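

Replacing the dichlorophenyl on the carbonyl carbon with methyl lowers the number in this assay rather than moving it toward the free amine, with a number 38 percentage points lower from compound 3 to compound 4 (beyond the scatter) and a number 26 percentage points lower from compound 1 to compound 4 (beyond the scatter) for the other amide. The acetyl amide gives the deepest fall from the free amine, a number 58 percentage points lower from compound 2 to compound 4 (beyond the scatter) in all, so either dichlorophenyl cap holds the number above the acetyl amide. No evidence given here accounts for this.

As far as these compounds go, whether an unsubstituted benzoyl, a monochlorobenzoyl or a longer acyl chain such as butanoyl would stay with the acetyl amide or rise toward the dichlorophenyl amides remains open.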